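The source may report more compounds than this note shows. Statements on the series, on what has been measured and on what is new or still open speak of the compounds shown alone.

Compound 1, `COc1ccc2cc(C(C)c3nnc4n3N=C(c3ccc(C(F)(F)F)cc3)CS4)ccc2c1`, was tested in a functional assay on MCF7 cells (Homo sapiens) for inhibition, read by sulforhodamine B assay, with a stated time of 72 h (a lower number here means a stronger inhibitor, a higher number a weaker inhibitor), where compound 1 gives 6900 nM. Among the compounds with values here, the only other measured compound is compound 2, `CC(c1ccc(-c2ccccc2)c(F)c1)c1nnc2n1N=C(c1ccc([N+](=O)[O-])cc1)CS2`, which in this assay gives 7800 nM. The two numbers of compound 1 and compound 2 lie within the usual scatter of each other, so nothing separates them beyond what repeated measurements of this kind would show; compound 1 simply carries the lower of the two numbers.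

The step followed here leads from compound 1 to compound 3, `COc1ccc2cc(C(C)c3nnc4n3N=C(c3ccc(F)cc3)CS4)ccc2c1`, whose value in this assay is not yet known. The change is fluoro in place of trifluoromethyl on an aromatic carbon, on an aromatic carbon of a six-membered aromatic ring of carbon only, para to a large group. Within the data shown here, no pair of measured compounds shows this change, so its effect cannot be read from the data. Among the measured compounds shown here, with only two measured numbers, close together, the expectation for the step from compound 1 to compound 3 is a 1.2-fold higher number from compound 1 to compound 3 (0.06 log units; within the scatter), a step of no size beyond the scatter. Compound 3 is therefore estimated at 8000 nM, within a range from 3000 nM to 22000 nM.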

Compound 3, half-maximal inhibitory concentration: 15800 nM
Beside the measured number, compound 3's estimate is 2.0-fold (0.30 log units) below it, and the stated range covers the measured number.
By their numbers in this assay, from the lowest: compounds 1 and 2 (each within the scatter of the next); then compound 3.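

In this assay, within the data shown here, the exchange of trifluoromethyl for fluoro on an aromatic carbon gives a 2.3-fold higher number from compound 1 to compound 3 (0.36 log units; beyond the scatter) and is the first single change that can be read, with the rest of compound 1 left as it stands. The earlier pair, compound 1 and compound 2, differ in more than one place and so could say nothing about any one group, whereas this step shows that the group at this position can move the number: the 4-fluorophenyl compound is the weaker inhibitor, by a modest margin. Nothing at hand explains why the number moves with this change.

The compounds shown leave open how other groups on this aromatic carbon would behave, such as a chlorine, a methoxy group, an amine or a carboxylic acid, and whether hydrogen alone would give a number nearer to that of compound 1 or of compound 3. On these data alone, it also stays open what the nitro group of compound 2 would give on the core of compound 1, a comparison that would set a third group at this position with nothing else changed.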